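Hydroxymethyl for Vinyl on the Carbamate-Bearing Compound

The source may hold more compounds than are shown below. What is called first, only, known or untested is meant among the compounds shown, and "the series" means these compounds.

Measured compounds:
Compound 1 `C=CC[C@@]12CCN[C@@H]1n1c3nc4ccc(O)cc4cc3c(=O)c3cccc2c31` gives 18700 nM in a functional assay on MSTO-211H cells (Homo sapiens) for inhibition, read by trypan blue exclusion, with a stated time of 72 h; a higher number here means a weaker inhibitor of growth, a lower number a stronger inhibitor of growth.
Compound 2 `COc1ccc2nc3c(cc2c1)c(=O)c1cccc2c1n3[C@H]1NCC[C@@]21CCO` gives 1900 nM in this assay.
Compound 3 `C=CC[C@@]12CCN(C(=O)OC(C)(C)C)[C@@H]1n1c3nc4ccc(O)cc4cc3c(=O)c3cccc2c31` gives 24100 nM in this assay.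

Compound 3 stands at the highest of the three numbers in this assay. Compound 1 sits nearest to it, within the scatter, while compound 2 sits furthest, well beyond it. The only measured step joining two of these compounds, a 1.3-fold higher number from compound 1 to compound 3 (0.11 log units; within the scatter), concerns the amine nitrogen and not the chain in question.

Compound 4 `CC(C)(C)OC(=O)N1CC[C@@]2(CCO)c3cccc4c(=O)c5cc6cc(O)ccc6nc5n(c34)[C@@H]12` arises from compound 3 by hydroxymethyl in place of vinyl on a saturated chain carbon bound to a saturated ring carbon. For the measured compounds named here, no measured step isolates this change. Compound 2 carries the 2-hydroxyethyl chain but also a methoxy in place of the hydroxyl, and it lacks the carbamate, so its low number against compound 1 cannot be attributed to the chain alone. Because a 1.3-fold higher number from compound 1 to compound 3 (0.11 log units; within the scatter) lay within the scatter, the carbamate on compound 4 is not expected to shift matters much either way. The account therefore expects a lower number for compound 4 in this assay, with wide uncertainty, estimated as a 3.4-fold lower number from compound 3 to compound 4 (0.54 log units; beyond the scatter). For compound 4 the estimate in this assay is 7000 nM, ranging from 1800 nM to 28000 nM.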

Compound 4, concentration for 50% growth inhibition: 13700 nM
Compound 4: middle estimate off by 2.0-fold (0.29 log units), on the low side, and the stated range covers the measured number.
By their numbers in this assay, from the lowest: compound 2; then compounds 4, 1 and 3 (each within the scatter of the next).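

In this assay, for the compounds shown here, hydroxymethyl in place of vinyl on a saturated chain carbon bound to a saturated ring carbon gives a 1.8-fold lower number from compound 3 to compound 4 (0.25 log units; within the scatter), the first reading of this change on its own, with the carbamate and the hydroxyl on the shared core held constant. On this pair, then, going from allyl to 2-hydroxyethyl leaves the number within the scatter, so the position shows no measurable response to this particular exchange, even though a hydrogen-bond donor and acceptor enter with the hydroxymethyl. Nothing among the data shown offers an explanation for this outcome.

Compound 2, at 1900 nM, differs from compound 4 in two places, the methoxy in place of the hydroxyl and the absent carbamate, so the compounds shown do not tell which of these goes with its number, or whether the two act only together. Also open, from the compounds shown here alone, are whether the same chain change reads alike on the free amine of compound 1, and whether an amine, a carboxylic acid or a longer chain at this position would move the number beyond the scatter.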